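Swapping the Dicyanoethenyl Group for a Sulfur-Bearing One

The source may hold more compounds than are shown below. What is called first, only, known or untested is meant among the compounds shown, and "the series" means these compounds.

Measured so far:
Compound 1 `CC(=O)c1ccc2c(c1)C(n1ccccc1=O)=CC(C)(C)O2` gives 6.65 in a functional assay (trachea) with Rattus norvegicus as the target; a higher number here means a more potent compound, by a factor of ten per unit of this negative logarithm, a lower number a less potent compound.
Compound 2 `CC1(C)C=C(n2ccccc2=O)c2cc(C=C(C#N)C#N)ccc2O1` gives 6.3 in this assay.

Among the compounds with values here, compound 2 holds the lower of the two numbers; its only neighbour is compound 1, and the single measured step is a number 0.35 log units lower from compound 1 to compound 2 (beyond the scatter), a modest loss that still lies beyond the scatter. The next compound, compound 3 `CC1(C)C=C(n2ccccc2=O)c2cc(C(=N)S)ccc2O1`, differs from compound 2 as follows: a group of 3 heavy atoms (1 carbon, 1 nitrogen, 1 sulfur; no ring) in place of a group of 6 heavy atoms (4 carbon, 2 nitrogen; no ring), on an aromatic carbon.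

Within the data shown here, only the step from compound 1 to compound 2 bears on this change, and only loosely: it also exchanges the group on that aromatic carbon, but no measured step introduces a sulfur-bearing group anywhere, so the direction is open. In this assay compound 3 is therefore expected to move little, a number 0.10 log units higher from compound 2 to compound 3 (within the scatter), within the scatter. The estimate for compound 3 is 6.4, with a range from 5.7 to 7.1.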

Compound 3, logarithm of the reciprocal of the active concentration, log(1/C): 5.96
The estimate for compound 3 lay 0.44 log units above the measured number, within the range that was stated.
By their numbers in this assay, from the lowest: compound 3; then compound 2; then compound 1.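

Compound 3 adds a second drop at this aromatic carbon in this assay: a number 0.34 log units lower from compound 2 to compound 3 (beyond the scatter), and measured against the acetyl group, a number 0.69 log units lower from compound 1 to compound 3 (beyond the scatter). This makes compound 3 the least potent of the three, and it shows that the number does not follow group size here, as the sulfur-bearing group and acetyl have the same heavy-atom count yet lie furthest apart, while the larger 2,2-dicyanoethenyl group falls between them. Nothing available explains why the sulfur-bearing group gives the lowest number.

Still open, as far as these compounds go, is whether the sulfur atom or the rest of the new group accounts for the drop. A primary amide at this position would test that directly, while a carboxylic acid or an amine would show how far the trend extends.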